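The source may report more compounds than this note shows. Statements on the series, on what has been measured and on what is new or still open speak of the compounds shown alone.

Compound 1 `O=C(Nc1cc(C(F)(F)F)cc(C(F)(F)F)c1)c1cc(Cl)c(F)cc1O` gives 730 nM
Compound 2 `N#Cc1ccc(NC(=O)c2ccc3cccnc3c2O)c(C#N)c1` gives 270 nM
Compound 3 `O=C(Nc1ccc(C(F)(F)F)cc1)c1ccc(F)cc1O` gives 800 nM

All three numbers come from a functional assay on Jurkat cells (Homo sapiens) for cytotoxicity, read by luminescence and CellTiter-Glo, with a stated time of 3 days (a higher number here means a weaker inhibitor, a lower number a stronger inhibitor), and no two of these compounds differ in one place only. Compound 1 at 730 nM lies within the scatter of compound 3 at 800 nM on this scale. Compound 2 at 270 nM gives a number beyond the scatter on the lower side of compound 1.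

The next compound to be read is compound 4 `O=C(Nc1cc(C(F)(F)F)cc(C(F)(F)F)c1)c1cc(Cl)c(-c2ccccc2)cc1O` with the core of compound 1 kept. It carries phenyl in place of fluoro on an aromatic carbon, ortho to a chloro group, meta to a hydroxy group and para to a large group (phenyl in place of fluoro on an aromatic carbon).

Within the data shown here, the three measured compounds offer no single-place step, so they give no direct guide to the size or direction of this change. The expectation in this assay is therefore no step beyond the scatter, with either direction left open and a wide margin kept. The expected step is a 1.0-fold higher number from compound 1 to compound 4 (0.01 log units; within the scatter) as an estimate only. For compound 4 the estimated value is 750 nM with an expected range of 220 nM to 2800 nM around it.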

Compound 4, half-maximal inhibitory concentration: 540 nM
For compound 4 the middle estimate is 1.4-fold (0.14 log units) above the measured one, within the range that was stated.
By their numbers in this assay, from the lowest: compounds 2, 4, 1 and 3 (each within the scatter of the next, the first and the last beyond it).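

In this assay, among these compounds, phenyl in place of fluoro on this aromatic carbon gives a 1.4-fold lower number from compound 1 to compound 4 (0.13 log units; within the scatter) and so stays within the scatter, which makes this the first single-place step. The position, ortho to a chloro group, meta to a hydroxy group and para to a large group, thus takes phenyl with 6 heavy atoms and a six-membered aromatic ring where fluoro has 1 heavy atom, and the read-out does not separate the two compounds. No measured evidence bears on why the number holds across this exchange.

An amine, a carboxylic acid or a longer alkyl chain on this same carbon would show whether the flat result extends beyond phenyl, since one step on one carbon cannot define the range of groups the position accepts. As far as these compounds go, this step is also read only on the core of compound 1, so it remains open whether phenyl in place of fluoro gives a similar result on the core of compound 3.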